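Double bond in place of triple bond on the chain

The compounds below may be only part of what the source reports. "The series", "measured", "known", "first", "only" and "open" are said of these compounds alone.

Compound 1 `COc1cc(Cc2nc3c(N)ncnc3n2CC2CCCO2)cc(OC)c1OC`: 91200 nM
Compound 2 `C#CCCn1c(Cc2cc(OC)c(OC)c(OC)c2)nc2c(N)nc(F)nc21`: 25100 nM
Compound 3 `CC/C=C/Cn1c(Cc2cc(OC)c(OC)c(OC)c2)nc2c(N)ncnc21`: 46800 nM

These three values come from a functional assay on MCF7 cells (Homo sapiens) for antiproliferative activity; a higher number here means a weaker inhibitor, a lower number a stronger inhibitor. Compound 2 stands at the low end of the three numbers; compound 3 lies within the scatter of it, compound 1 beyond it. Compound 4 `C=CCCn1c(Cc2cc(OC)c(OC)c(OC)c2)nc2c(N)nc(F)nc21` differs from compound 2 by vinyl in place of ethynyl on a saturated chain carbon, two bonds along the chain from an aromatic nitrogen. Among the compounds with values here, only one measured step speaks to a change of this kind: a 1.9-fold lower number from compound 1 to compound 3 (0.29 log units; within the scatter), in which an unsaturated chain replaced a ring and the number hardly moved. Compound 3, with a double bond in its chain, and compound 2, with a triple bond in its chain, give values within the scatter of each other. No step beyond the scatter is therefore expected for a 1.2-fold higher number from compound 2 to compound 4 (0.08 log units; within the scatter). Compound 4 is estimated at 30000 nM, within 12000 nM to 75000 nM.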

Compound 4, half-maximal inhibitory concentration: 33100 nM
Estimate against measurement, compound 4: 1.1-fold (0.04 log units) below, and the stated range covers the measured number.
By their numbers in this assay, from the lowest: compounds 2, 4, 3 and 1 (each within the scatter of the next, the first and the last beyond it).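

In this assay vinyl in place of ethynyl on a saturated chain carbon, two bonds along the chain from an aromatic nitrogen, gives a step within the scatter (a 1.3-fold higher number from compound 2 to compound 4 (0.12 log units; within the scatter)). Within the data shown here, this is the first comparison in which only the chain end differs, and it shows that the but-3-en-1-yl and but-3-yn-1-yl chains cannot be told apart here. Nothing available explains this result. The compounds shown leave open whether a fully saturated butyl chain, a longer chain or a terminal amine at this place would give a step beyond the scatter.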